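The compounds below may be only part of what the source reports. "The series", "measured", "known", "first", "only" and "open" are said of these compounds alone.

Compound 3 `NC(=O)Cc1cc(=O)oc2cc(OCc3cccc(F)c3)ccc12` gives 50 nM in an assay for inhibition of Amine oxidase [flavin-containing] B (Rattus norvegicus) (a higher number here means a weaker inhibitor, a lower number a stronger inhibitor), the lowest of the three numbers measured. Compound 1 `C[C@H](Nc1cc(=O)oc2cc(OCc3ccccc3)ccc12)C(N)=O` gives 680 nM in this assay, and compound 2 `NC(=O)[C@@H]1CCCN1Cc1cc(=O)oc2cc(OCc3cccc(F)c3)ccc12` gives 850 nM. Within the data shown here, the only change measured at a single place is a 17-fold lower number from compound 2 to compound 3 (1.23 log units; beyond the scatter); it concerns the group on the saturated chain carbon bound to an aromatic carbon, a different part of the shared core from the one altered next. Compound 4 `NC(=O)Cc1cc(=O)oc2cc(OCc3ccncc3)ccc12` differs from compound 3 by pyridin-4-yl in place of 3-fluorophenyl on a saturated chain carbon bound to an oxygen on an aromatic ring. Among the measured compounds shown here, no measured step touches this part of the molecule, and compound 1 and compound 2 each differ from compound 3 in two places, so they give no clean comparison for this change. For the measured compounds named here, the expectation for compound 4 therefore rests on no direct precedent and carries a wide range, with a modest move toward a higher number regarded as somewhat more likely than a lower one. Compound 4 is estimated at 150 nM in this assay, with a range from 40 nM to 600 nM. The step expected is a 3.0-fold higher number from compound 3 to compound 4 (0.48 log units; beyond the scatter).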

Compound 4, half-maximal inhibitory concentration: 2000 nM
The estimate for compound 4 lay 13-fold (1.12 log units) below the measured number, and the stated range ends below it.
By their numbers in this assay, from the lowest: compound 3; then compounds 1 and 2 (each within the scatter of the next); then compound 4.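

In this assay, among these compounds, the change to pyridin-4-yl in place of 3-fluorophenyl, on a saturated chain carbon bound to an oxygen on an aromatic ring, gives a 40-fold higher number from compound 3 to compound 4 (1.60 log units; beyond the scatter) and shows for the first time that the number is sensitive to the group at this place. The swap is not a single edit: the fluorine leaves, a ring nitrogen enters, and the group goes from no hydrogen-bond acceptors to one, so this pair cannot show which of these matters. Nothing available explains the loss.

Still open, on these data alone, is whether a plain phenyl at this place, on the core of compound 3, would stay close to compound 3 or fall toward compound 4. A pyridin-3-yl or pyridin-2-yl group would show whether the placement of the ring nitrogen matters.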